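A few compounds are considered here, and "the series" means these few. Any claim that something is new, unique, unknown or untested is made for them only; others in the source may bear on it.

Measured compounds:
compound 1, `C=CCCn1cnc2c1c(=O)n(C)c(=O)n2CCC`: 6000 nM
compound 2, `CCCn1c(=O)n(C)c(=O)c2c1ncn2CCOC`: 12400 nM

Of the compounds shown here, two have been measured in an assay on Cerebral cortex for binding affinity to adenosine receptor A1 (Cavia porcellus), read by radioligand binding; a lower number here means a stronger inhibitor, a higher number a weaker inhibitor. Compound 1 gives 6000 nM, and compound 2 gives 12400 nM. Among the measured compounds shown here, of the two, compound 2 has the higher number; the only step in this set, a 2.1-fold higher number from compound 1 to compound 2 (0.32 log units; beyond the scatter), separates it from compound 1.

The next compound, compound 3, has the structure `CCCn1c(=O)n(C)c(=O)c2c1ncn2CCOCC`. It differs from compound 2 in one place: methyl in place of hydrogen on a saturated chain carbon bound to an oxygen on a saturated carbon. Cut one bond further out, the change reads methoxy to ethoxy on the same saturated chain.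

For the measured compounds named here, no measured step bears directly on this change. Going by the values given here, the one step in the data, from compound 1 to compound 2, replaces a vinyl group by a methoxy group and so speaks to a different alteration; it was modest in size. With nothing in the data that resembles the lengthening of the alkoxy group, no direction can be read from the measured compounds, and no step beyond the usual scatter in this assay is expected.

Compound 3 is therefore estimated at 12000 nM, with a range from 5000 nM to 30000 nM. This estimate corresponds to an expected step of a 1.0-fold lower number from compound 2 to compound 3 (0.01 log units; within the scatter).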

Compound 3, inhibition constant: 24300 nM
For compound 3 the middle estimate is 2.0-fold (0.31 log units) below the measured one; low and high end bracket the measured number.
By their numbers in this assay, from the lowest: compound 1; then compounds 2 and 3 (each within the scatter of the next).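

In this assay, among the compounds shown here, the change from methoxy to ethoxy on the same saturated chain gives a 2.0-fold higher number from compound 2 to compound 3 (0.29 log units; within the scatter) and so offers the first direct comparison of two alkoxy groups here; the added methyl, on a saturated chain carbon bound to an oxygen on a saturated carbon, leaves the reading within the scatter. The comparison with the vinyl compound is clearer, since going from its vinyl group to the ethoxy group gives a 4.1-fold higher number from compound 1 to compound 3 (0.61 log units; beyond the scatter) and thus joins a 2.1-fold higher number from compound 1 to compound 2 (0.32 log units; beyond the scatter) in placing both alkoxy compounds on the weaker side of compound 1 by more than the scatter. No supporting measurement accompanies these readings, so the data give no explanation for either step.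

From the compounds shown here alone, what remains open is whether a longer chain on the oxygen, such as propoxy or butoxy, would leave the number within the scatter of compound 3 or carry it further from compound 1. Going by these compounds, it is equally open how an amine or a hydroxyl group at the end of this chain would read in this assay when set against the alkoxy and vinyl compounds.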